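The source may report more compounds than this note shows. Statements on the series, on what has been measured and on what is new or still open speak of the compounds shown alone.

Working notes on the series

In a functional assay on B16-F10 cells (Mus musculus) for cytotoxicity, read by CCK-8 assay, with a stated time of 48 h (on this read-out lower numbers stand for stronger inhibition and higher numbers for weaker inhibition), compound 1 `N=C(N)NS(=O)(=O)c1ccc(/N=C/c2c(Cl)c3ccccc3oc2=O)cc1` gives 180 nM. Compound 2 `Cc1cc(C)nc(NS(=O)(=O)c2ccc(/N=C/c3c(Cl)c4ccccc4oc3=O)cc2)n1` differs from compound 1 by a group of 8 heavy atoms (6 carbon, 2 nitrogen; one six-membered aromatic ring with 2 hetero atoms) in place of a group of 3 heavy atoms (1 carbon, 2 nitrogen; no ring), on a sulfonamide nitrogen and in this assay compound 2 gives 170 nM; the step of a 1.1-fold lower number from compound 1 to compound 2 (0.02 log units; within the scatter). Compound 3 `Cc1ccc2oc(=O)c(/C=N/c3ccc(S(=O)(=O)NC(=N)N)cc3)c(Cl)c2c1` differs from compound 1 by methyl in place of hydrogen on an aromatic carbon, and in this assay compound 3 gives 240 nM; the step of a 1.3-fold higher number from compound 1 to compound 3 (0.12 log units; within the scatter). All three measured values lie within the scatter of one another, so no order among compounds 1, 2 and 3 is claimed.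

Compound 4 `Cc1ccc2oc(=O)c(/C=N/c3ccc(S(=O)(=O)Nc4nc(C)cc(C)n4)cc3)c(Cl)c2c1` is not yet measured in this assay. It differs from compound 3 by a group of 8 heavy atoms (6 carbon, 2 nitrogen; one six-membered aromatic ring with 2 hetero atoms) in place of a group of 3 heavy atoms (1 carbon, 2 nitrogen; no ring), on a sulfonamide nitrogen. This is the same change as that from compound 1 to compound 2: the group that leaves, the group that enters and the place on the sulfonamide nitrogen whose other neighbour is the sulfonyl sulfur all match word for word, and it occurs twice among the compounds shown. The cores of compound 3 and compound 4 differ from the core of compound 1 by methyl in place of hydrogen on an aromatic carbon, a difference that made only a small step.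

For compound 3 to compound 4 the expected step in this assay is a 1.1-fold lower number from compound 3 to compound 4 (0.04 log units; within the scatter), beside the earlier 1.1-fold lower number from compound 1 to compound 2 (0.02 log units; within the scatter), because the same change on the core of compound 1 gave a 1.1-fold lower number from compound 1 to compound 2 (0.02 log units; within the scatter). The expectation rests on a single earlier instance, so the spread is kept wide. Compound 4 is therefore estimated at 220 nM in this assay, with a range from 110 nM to 450 nM.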

Compound 4, half-maximal inhibitory concentration: 300 nM
Beside the measured number, compound 4's estimate is 1.4-fold (0.13 log units) below it, within the range that was stated.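

In this assay, putting 4,6-dimethylpyrimidin-2-yl on the sulfonamide nitrogen of the methyl-bearing core gives a 1.3-fold higher number from compound 3 to compound 4 (0.10 log units; within the scatter), and this exchange reads the same on both cores: the same change on two cores in this assay, a 1.1-fold lower number (0.02 log units; within the scatter) from compound 1 to compound 2 and a 1.3-fold higher number (0.10 log units; within the scatter) from compound 3 to compound 4, 1.3-fold (0.12 log units) apart, within the scatter of two such steps. Methyl in place of hydrogen on an aromatic carbon, read on the pair that carries 4,6-dimethylpyrimidin-2-yl, gives a 1.8-fold higher number from compound 2 to compound 4 (0.25 log units; within the scatter), and this change also reads the same on both cores: the same change on two cores in this assay, a 1.3-fold higher number (0.12 log units; within the scatter) from compound 1 to compound 3 and a 1.8-fold higher number (0.25 log units; within the scatter) from compound 2 to compound 4, 1.3-fold (0.12 log units) apart, within the scatter of two such steps. Within these four compounds, each change can be carried from one core to the other without a difference that stands out from the scatter, but every step is itself within the scatter, so this shows only that neither change moved the number measurably here and does not show that a step of real size would carry over, nor that the two changes add up in general.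

The compounds shown leave open how a carboxylic acid or a longer alkyl chain on the sulfonamide nitrogen would read in this assay. They also leave open whether a group such as methoxy or ethyl in place of the methyl on the aromatic carbon would give a step beyond the scatter, and whether such a step would hold on both cores.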